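Swapping a pyridyl for a methylthiazolyl on the ether chain

The compounds below may be only part of what the source reports. "The series", "measured", "known", "first", "only" and "open" are said of these compounds alone.

The three measured compounds share one core and differ only in the group on the ether oxygen of the aryl ring. Compound 1 `Cc1cc(CCOc2ccc(-c3c(C)nc(C)c([C@H](OC(C)(C)C)C(=O)O)c3N3CCC(C)(C)CC3)cc2)ccc1F` reaches the limit of an ADME assay on microsomes from liver (Rattus norvegicus) for metabolic stability, read by LC-MS, tested at 0.5 uM (on this read-out higher numbers stand for a longer-lived compound and lower numbers for a shorter-lived compound), reported as > 2 h, which is a limit and not a number. Compound 2 `Cc1nc(C)c([C@H](OC(C)(C)C)C(=O)O)c(N2CCC(C)(C)CC2)c1-c1ccc(OC2COCC2c2ccc(F)cc2)cc1` likewise sits at the limit of this assay, reported as > 2 h. Compound 3 `Cc1nc(C)c([C@H](OC(C)(C)C)C(=O)O)c(N2CCC(C)(C)CC2)c1-c1ccc(OCCc2cccnc2)cc1` is the only one of the three with an actual number, giving 0.783 h in this assay. It thus stands as the one readable point among the three, which is borne out by the limit of > 2 h in this assay, at which 2 of the 3 values shown sit. The two steps onto it are an at least 2.5-fold lower number from compound 1 to compound 3 (0.40 log units; beyond the scatter) and an at least 2.5-fold lower number from compound 2 to compound 3 (0.40 log units; beyond the scatter), while the step that the two limits leave unreadable from compound 1 to compound 2 cannot be sized.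

Compound 4 `Cc1nc(CCOc2ccc(-c3c(C)nc(C)c([C@H](OC(C)(C)C)C(=O)O)c3N3CCC(C)(C)CC3)cc2)cs1` carries the change (2-methyl-1,3-thiazol-4-yl in place of pyridin-3-yl on a saturated chain carbon, two bonds along the chain from an oxygen on an aromatic ring). Among the compounds with values here, no measured step joins a pyridinyl to a thiazolyl group; the two readable steps both lead onto the pyridinyl of compound 3 and both lowered the number, so moving away from that group gives some ground to expect a rise. The step of a 1.7-fold higher number from compound 3 to compound 4 (0.22 log units; within the scatter) is therefore expected in this assay, with wide uncertainty. Compound 4 is expected to give about 1.3 h, between 0.6 h and 2.5 h.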

Compound 4, half-life: 1.75 h
The estimate for compound 4 lay 1.3-fold (0.13 log units) below the measured number; measured number inside the range.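

In this assay, 2-methyl-1,3-thiazol-4-yl in place of pyridin-3-yl on a saturated chain carbon, two bonds along the chain from an oxygen on an aromatic ring, gives a 2.2-fold higher number from compound 3 to compound 4 (0.35 log units; beyond the scatter). The earlier readable steps all led down onto the pyridin-3-yl group; this one shows that a different nitrogen-bearing aromatic ring at the same place, with the same count of heavy atoms, ends higher, so a ring nitrogen on this chain does not by itself fix the number at the level of compound 3. Against the two compounds at the limit the floors are an at least 1.1-fold lower number from compound 2 to compound 4 (0.05 log units; that floor lies within the scatter) and an at least 1.1-fold lower number from compound 1 to compound 4 (0.05 log units; that floor lies within the scatter), and these steps cannot be read for their true size because of a limit and not a number: the limit of > 2 h in this assay, at which 2 of the 4 values shown sit.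

The compounds shown leave open whether the methyl group or the thiazole ring goes with the higher number, as the two enter together in compound 4, and a 1,3-thiazol-4-yl without the methyl would separate them. They also leave open whether a pyridin-2-yl or a pyrimidin-5-yl on the same chain would sit nearer compound 3 or compound 4.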